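The source may hold more compounds than are shown below. What is called first, only, known or untested is meant among the compounds shown, and "the series" means these compounds.

Measured compounds and their values in an assay on isolated protein for inhibition of Aromatase (Homo sapiens), read by fluorescence, tested at 1 uM; a lower number here means less inhibition, a higher number more inhibition at the concentration tested (going by the name of the read-out):
compound 1, `N#Cc1ccc(Oc2cccnc2)c(Oc2cccnc2)c1`, gives 82%;
compound 2, `NC(=O)c1ccc(-n2ccc3ccncc32)cc1`, gives 60%;
compound 3, `N#Cc1ccc(-n2ccc3ccncc32)cc1`, gives 94%.

Among these three, compound 3 stands highest, above compound 1 and further above compound 2, both gaps beyond the usual scatter. Among the measured compounds shown here, the one single-change step that has been measured runs a number 34 percentage points higher from compound 2 to compound 3 (beyond the scatter), and it concerns the group on the aromatic ring rather than a methyl. Compound 4, `Cc1cc(-n2ccc3ccncc32)ccc1C#N`, differs from compound 3 by methyl in place of hydrogen on an aromatic carbon. For the measured compounds named here, no measured step bears on such an addition, so the expectation rests on compound 3 alone, whose value 94% already lies near the top of this assay. A step of a number 2 percentage points lower from compound 3 to compound 4 (within the scatter) is therefore expected, within the scatter. Compound 4 is estimated at 92%, between 78% and 99%.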

Compound 4, a percentage reported as inhibition, at one concentration (the size of the read-out at that concentration, not a potency): > 99%
Compound 4: only a limit was reported (the forecaster's own chance of this, stated with the estimate: 0%); at least 7 percentage points between middle value and limit.
By their numbers in this assay, from the lowest: compound 2; then compound 1; then compound 3. At a limit, above all of these: compound 4.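

In this assay, methyl in place of hydrogen on an aromatic carbon, ortho to the cyano group, gives a number at least 5 percentage points higher from compound 3 to compound 4 (that floor lies within the scatter). The earlier compounds shown here showed only a change at the cyano group itself, whereas this step shows that the ring carbon ortho to it can carry a methyl with no drop in inhibition. The result for compound 4 is a limit, not a number: the limit of > 99% in this assay, at which 1 of the 4 values shown sits.

From the compounds shown here alone, how far the methyl raises inhibition stays open. So does whether an ethyl chain, a methoxy group or an amine at this place would hold inhibition as well.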